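A few compounds are considered here, and "the series" means these few. Any claim that something is new, unique, unknown or untested is made for them only; others in the source may bear on it.

Three nucleoside analogues have been tested for their ability to stop the growth of lung cancer cells in a functional assay on A549 cells (Homo sapiens), read by MTT assay, with a stated time of 72 h; a higher number here means a weaker inhibitor, a lower number a stronger inhibitor. Compound 1 `COc1nc(N)nc2c1c(-c1cc3ccccc3o1)cn2[C@@H]1O[C@H](CO)[C@@H](O)[C@H]1O` gives only a limit there, > 20000 nM. Compound 3 `Nc1nc(N)c2c(-c3ccoc3)cn([C@@H]3O[C@H](CO)[C@@H](O)[C@H]3O)c2n1` likewise reaches only the limit, > 20000 nM. Compound 2 `COc1ncnc2c1c(I)cn2[C@@H]1O[C@H](CO)[C@@H](O)[C@H]1O`, the starting point here, also stops at the limit, > 20000 nM. Among the measured compounds shown here, all three values so far sit at the limit of > 20000 nM in this assay, at which 3 of the 3 values shown sit, so compound 2 stands no differently from the other two. Compound 4 `COc1ncnc2c1c(-c1ccccc1)cn2[C@@H]1O[C@H](CO)[C@@H](O)[C@H]1O` differs from compound 2 by phenyl in place of iodo on an aromatic carbon. For the measured compounds named here, no measured pair shows what this swap does, so no shift beyond the scatter is expected in either direction. Compound 4 is therefore expected to stay near the limit, estimated at 25000 nM (range 5000 nM to 120000 nM), a step that the limit leaves unreadable from compound 2 to compound 4 expected to lie within the scatter.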

Compound 4, half-maximal inhibitory concentration: > 20000 nM
Compound 4 gave a limit, no number (the forecaster's own chance of this, stated with the estimate: 75%); the middle value is on the limit's open side.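

Among the compounds shown here, compound 2 and compound 4 both stop at a limit, so no step between them can be read: the limit of > 20000 nM in this assay, at which 4 of the 4 values shown sit. The compounds shown leave open what phenyl in place of iodo actually does in this assay.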